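Adding one fluoro to compound 1

The source may report more compounds than this note shows. Statements on the series, on what has been measured and on what is new or still open speak of the compounds shown alone.

Compound 1 `O=C(CN1CCN(C(=O)c2ccc(F)cc2)CC1)N1CCN(CCCc2c[nH]c3ccccc23)CC1` gives 141000 nM
Compound 2 `O=C(CN1CCN(C(=O)c2cccc(Cl)c2)CC1)N1CCN(CCCc2c[nH]c3ccccc23)CC1` gives 99100 nM
Compound 3 `COc1cccc(C(=O)N2CCN(CC(=O)N3CCN(CCCc4c[nH]c5ccccc45)CC3)CC2)c1` gives 143000 nM

All three numbers come from an ADME assay on HEK293 cells (Homo sapiens) for cytotoxicity, read by MTT assay, with a stated time of 72 h (on this read-out higher numbers stand for weaker inhibition and lower numbers for stronger inhibition), and lie within the usual scatter of one another, so compound 1 stands level with the other two. Compound 4 `O=C(CN1CCN(C(=O)c2ccc(F)cc2)CC1)N1CCN(CCCc2c[nH]c3ccc(F)cc23)CC1` differs from compound 1 by a single change fluoro in place of hydrogen on an aromatic carbon that turns 1H-indol-3-yl into 5-fluoro-1H-indol-3-yl. For the measured compounds named here, two measured steps bear on it: a 1.4-fold lower number from compound 1 to compound 2 (0.15 log units; within the scatter) and a 1.0-fold higher number from compound 1 to compound 3 (0.01 log units; within the scatter) both lie within the scatter. Going by the values given here, those swaps concern the group on a carbonyl carbon, so no measured step touches the 1H-indol-3-yl itself and the guidance is only indirect. No step beyond the scatter is therefore expected in this assay for this change. The step expected is a 1.2-fold lower number from compound 1 to compound 4 (0.07 log units; within the scatter) by this estimate. Compound 4 is expected near 120000 nM with 60000 nM to 220000 nM as the estimated range.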

Compound 4, half-maximal inhibitory concentration: 102000 nM
Estimate against measurement, compound 4: 1.2-fold (0.07 log units) above; low and high end bracket the measured number.
By their numbers in this assay, from the lowest: compounds 2, 4, 1 and 3 (each within the scatter of the next).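

In this assay, fluoro in place of hydrogen, turning 1H-indol-3-yl into 5-fluoro-1H-indol-3-yl, gives a 1.4-fold lower number from compound 1 to compound 4 (0.14 log units; within the scatter). For the compounds shown here, this is the first measured change on the 1H-indol-3-yl rather than on the group at the carbonyl carbon, and at this position a single fluoro leaves the reading level with that of compound 1. No supporting measurement offers an explanation for this result. Still open, on these data alone, is how a different group at this same position, such as an amine or a carboxylic acid, would read.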